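This account rests on a few compounds, and the source may have more. Where it says the series, first, only, none or still open, it means among the compounds named here.

Working notes on the series.

Compound 1 `COc1cc(O)c(C(=O)/C=C/c2ccc(OC)c(OCc3cn(-c4ccc(F)cc4F)nn3)c2)c(OC)c1` and compound 2 `COc1cc(OC)c2c(=O)cc(-c3ccc(OCc4cn(-c5ccc(F)cc5F)nn4)c(OC)c3)oc2c1` share the diaryl ether-linked triazole bearing a 2,4-difluorophenyl group but differ in their cores. In an ADME assay on Huh-7 cells (Homo sapiens) for cytotoxicity, read by MTT assay, with a stated time of 72 h (a lower number here means that less compound is tolerated, a higher number that more compound is tolerated), compound 1 gives only a limit of the assay, > 100 ug/mL. In this assay compound 2 likewise gives only a limit, > 100 ug/mL. For the measured compounds named here, compound 2 therefore stands at the limit of > 100 ug/mL in this assay, at which 2 of the 2 values shown sit, and no measured step is available to scale the next change.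

Compound 3 `COc1cc(OC)c2c(=O)cc(-c3ccc(OCc4cn(-c5ccc(Cl)cc5)nn4)c(OC)c3)oc2c1` carries the core of compound 2 with 4-chlorophenyl in place of 2,4-difluorophenyl on an aromatic nitrogen. With two limits as the only reference, no step beyond the scatter is expected in this assay from compound 2 to compound 3, the expected step being a step that the limit leaves unreadable from compound 2 to compound 3. Compound 3 is therefore estimated to sit at 150 ug/mL, within a range of 60 ug/mL to 350 ug/mL, most probably again reported only as a limit in this assay.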

Compound 3, half-maximal cytotoxic concentration: > 100 ug/mL
Compound 3 ended at the assay's limit; the forecaster's own chance of this, stated with the estimate: 80%; the middle value does not contradict the limit.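

No step can be read from compound 2 to compound 3, as both give only a limit in this assay, and the series offers no measured value to scale from: the limit of > 100 ug/mL in this assay, at which 3 of the 3 values shown sit.

The compounds shown leave open how much compound is tolerated past that limit, and whether 4-chlorophenyl in place of 2,4-difluorophenyl on an aromatic nitrogen makes any difference.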